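The source may report more compounds than this note shows. Statements on the series, on what has been measured and on what is new or still open speak of the compounds shown alone.

Measured so far in a physicochemical assay for lipophilicity, read by HPLC, measured as chromatographic lipophilicity, at pH 7.4; a higher number here means a more lipophilic compound, a lower number a more polar compound:
Compound 1 `COc1cccc(NC(=O)c2nnn(Cc3ccc(C#N)cc3)c2N)c1`: 2.3
Compound 2 `COc1cccc(NC(=O)c2nnn(Cc3ccccc3)c2N)c1`: 2.6

For the measured compounds named here, compound 2 stands within the scatter of compound 1, the only other compound measured. Compound 3 `COc1cccc(NC(=O)c2nnn(Cc3ccc(-n4cccn4)cc3)c2N)c1` differs from compound 2 by 1H-pyrazol-1-yl in place of hydrogen on an aromatic carbon and in nothing else. Going by the values given here, one measured step bears on this, a number 0.30 log units higher from compound 1 to compound 2 (within the scatter), and it involves cyano rather than 1H-pyrazol-1-yl, so it is only a loose guide. A small upward move, not clearly beyond the scatter, is therefore expected, and the estimated step is a number 0.30 log units higher from compound 2 to compound 3 (within the scatter). In this assay the estimate for compound 3 is 2.9, with an expected range from 2.5 to 3.3.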

Compound 3, distribution coefficient: 2.4
Beside the measured number, compound 3's estimate is 0.50 log units above it; measured number below the stated range.
By their numbers in this assay, from the lowest: compounds 1, 3 and 2 (each within the scatter of the next).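

On the aromatic carbon para to a large group, 1H-pyrazol-1-yl leaves the number in this assay within the scatter, with a number 0.20 log units lower from compound 2 to compound 3 (within the scatter) and a number 0.10 log units higher from compound 1 to compound 3 (within the scatter) as its two steps. Hydrogen, cyano and 1H-pyrazol-1-yl at this place thus give numbers that cannot be told apart, even though the last brings in a whole five-membered aromatic ring. No measured evidence bears on why this is so.

On these data alone, whether an amine or a carboxylic acid at this place would move the number beyond the scatter stays open.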